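Trimming the isopropyl to methyl on the shared core

The compounds below may be only part of what the source reports. "The series", "measured", "known", "first", "only" and "open" are said of these compounds alone.

Measured so far:
compound 1 `CC(C)c1ccc(-c2nc(SCc3cn(CC(=O)NC(=O)Nc4ccccn4)nn3)nc(Nc3cccc(Cl)c3)c2C#N)cc1`: 18000 nM
compound 2 `Cc1cccc(Nc2nc(SCc3cn(CC(=O)NC(=O)Nc4ccccn4)nn3)nc(-c3ccc(C(C)C)cc3)c2C#N)c1`: > 64000 nM
compound 3 `CC(C)c1ccc(Nc2nc(SCc3cn(CC(=O)NC(=O)Nc4ccccn4)nn3)nc(-c3ccc(C(C)C)cc3)c2C#N)cc1`: 28600 nM

In a functional assay on MCF7 cells (Homo sapiens) for inhibition, read by MTT assay, with a stated time of 72 h (on this read-out lower numbers stand for stronger inhibition and higher numbers for weaker inhibition), compound 1 gives 18000 nM, and compound 3 gives 28600 nM. Compound 2 reaches only a limit in this assay, > 64000 nM (the limit of > 64000 nM in this assay, at which 1 of the 3 values shown sits). Among the two numbers, compound 3 sits highest, but its gap to compound 1 is within the scatter, so no order between them can be claimed.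

Compound 4 `Cc1ccc(-c2nc(SCc3cn(CC(=O)NC(=O)Nc4ccccn4)nn3)nc(Nc3ccc(C(C)C)cc3)c2C#N)cc1` differs from compound 3 in one place: methyl in place of isopropyl on an aromatic carbon. Among the compounds with values here, none of the measured steps touches this ring; they all concern the group on the nitrogen, where an at least 3.5-fold higher number from compound 1 to compound 2 (0.55 log units; beyond the scatter), a 1.6-fold higher number from compound 1 to compound 3 (0.20 log units; within the scatter) and an at least 2.2-fold lower number from compound 2 to compound 3 (0.34 log units; beyond the scatter). Those steps show that swapping small groups on an aryl ring can move this assay modestly, but give no direction for the ring carrying the isopropyl. Compound 4 is therefore expected to stay near compound 3, with a 1.2-fold higher number from compound 3 to compound 4 (0.09 log units; within the scatter) and a fair chance of only a limit. The estimate for compound 4 is 35000 nM, ranging from 15000 nM to 80000 nM.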

Compound 4, half-maximal inhibitory concentration: > 64000 nM
Compound 4: no number, only a limit (the forecaster's own chance of this, stated with the estimate: 30%); middle value at least 1.8-fold (0.26 log units) away from the limit.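

Going from 4-isopropylphenyl to 4-methylphenyl, with the group on the nitrogen held the same, gives an at least 2.2-fold higher number from compound 3 to compound 4 (0.34 log units; beyond the scatter) in this assay, which shows that this ring, untouched by the earlier steps, also bears on the read-out. Because the step ends at a limit, it gives only a minimum size and not a full measure of the change. Compound 4 has a limit and not a number, and it is the second compound to do so: the limit of > 64000 nM in this assay, at which 2 of the 4 values shown sit.

Only isopropyl and methyl stand at this position in the compounds shown, so it remains open how a hydrogen, a methoxy group, an amine or a longer chain such as n-butyl would read there. Going by these compounds, whether the same trim behaves alike with the 3-chlorophenyl group of compound 1 on the nitrogen also stays open.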